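This account rests on a few compounds, and the source may have more. Where it says the series, first, only, none or still open, it means among the compounds named here.

Measured so far in a functional assay on DU-145 cells (Homo sapiens) for antiproliferative activity, read by propidium iodide staining, with a stated time of 96 h; a higher number here means a weaker inhibitor, a lower number a stronger inhibitor
compound 1 `CC(O)(COc1cccc(C(F)(F)F)c1)C(=O)Nc1cccc(S(F)(F)(F)(F)F)c1` gives 31700 nM
compound 2 `CC(O)(COc1ccc(C#N)cc1)C(=O)Nc1cccc(S(F)(F)(F)(F)F)c1` gives 42600 nM

Compound 2 has only compound 1 to stand against, and the two values lie within the scatter of each other, so neither ranks over the other. Compound 3 `CC(O)(COc1ccc(C#N)c(F)c1)C(=O)Nc1cccc(S(F)(F)(F)(F)F)c1` is still unmeasured. Its difference from compound 2 is fluoro in place of hydrogen on an aromatic carbon in words fluoro in place of hydrogen on an aromatic carbon, turning 4-cyanophenyl into 4-cyano-3-fluorophenyl. Among the compounds with values here, no measured step tests this fluoro directly. Within the data shown here, the only step bearing on it is the exchange of 3-(trifluoromethyl)phenyl for 4-cyanophenyl (a 1.3-fold higher number from compound 1 to compound 2 (0.13 log units; within the scatter)) and that step stays within the scatter. On that basis no step beyond the scatter is expected in this assay in either direction. The expected step is a 1.1-fold lower number from compound 2 to compound 3 (0.05 log units; within the scatter) on this estimate. Compound 3 is estimated at 38000 nM as a middle value (expected range 17000 nM to 80000 nM)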

Compound 3, half-maximal inhibitory concentration: 74800 nM
Compound 3: the middle estimate sits 2.0-fold (0.29 log units) below what was measured; low and high end bracket the measured number.
By their numbers in this assay, from the lowest: compounds 1, 2 and 3 (each within the scatter of the next, the first and the last beyond it).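

In this assay the fluoro ortho to a cyano group now has a direct test, and a 1.8-fold higher number from compound 2 to compound 3 (0.24 log units; within the scatter) leaves this single change unresolved. Within the data shown here, the exchange of 3-(trifluoromethyl)phenyl for 4-cyano-3-fluorophenyl gives the first step to pass the scatter, modest in size, with a 2.4-fold higher number from compound 1 to compound 3 (0.37 log units; beyond the scatter) as its reading, while the same exchange with 4-cyanophenyl stayed within the scatter. No measurement at hand accounts for either step.

Going by these compounds, whether a chloro, a methoxy or an amino group on the same aromatic carbon would give a step beyond the scatter remains open. Also open, on these data alone, is how the fluoro reads on the 3-(trifluoromethyl)phenyl group, or with a methoxy in place of the hydroxyl of the shared core.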